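Trimming the Ester Chain of an Aminomethyl Benzoate

This account rests on a few compounds, and the source may have more. Where it says the series, first, only, none or still open, it means among the compounds named here.

Compound 1, `NCc1ccc(C(=O)OCCc2ccccc2)cc1`: 600000000 nM
Compound 2, `NCc1ccc(C(=O)OCc2ccccc2)cc1`: 30000000 nM
Compound 3, `CCCCCCOC(=O)c1ccc(CN)cc1`: 300000000 nM

All three were measured in an assay on isolated protein for inhibition of serine protease 1 (Homo sapiens); on this read-out lower numbers stand for stronger inhibition and higher numbers for weaker inhibition. Compound 3 gives the second highest of the three numbers; its nearest neighbour is reached by a 2.0-fold lower number from compound 1 to compound 3 (0.30 log units; within the scatter), its furthest by a 10-fold higher number from compound 2 to compound 3 (1.00 log units; beyond the scatter). Compound 4, `CCOC(=O)c1ccc(CN)cc1`, differs from compound 3 by hydrogen in place of butyl on a saturated chain carbon, two bonds along the chain from an oxygen next to a carbonyl group. The two measured steps change the same part of the ester, but neither simply shortens the chain, so they set no firm direction. Because the closest comparison is a 2.0-fold lower number from compound 1 to compound 3 (0.30 log units; within the scatter), little movement is expected, and the step to compound 4 is estimated as a 1.7-fold higher number from compound 3 to compound 4 (0.22 log units; within the scatter). Compound 4 is therefore expected near 500000000 nM, within a range from 100000000 nM to 2000000000 nM.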

Compound 4, inhibition constant: 357000000 nM
Beside the measured number, compound 4's estimate is 1.4-fold (0.15 log units) above it; measured number inside the range.
By their numbers in this assay, from the lowest: compound 2; then compounds 3, 4 and 1 (each within the scatter of the next).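

At this chain carbon, hydrogen in place of butyl gives a 1.2-fold higher number from compound 3 to compound 4 (0.08 log units; within the scatter) and hydrogen in place of phenyl gives a 1.7-fold lower number from compound 1 to compound 4 (0.23 log units; within the scatter), so neither group separates measurably from hydrogen here. Methyl in place of phenyl on the saturated chain carbon bound to the oxygen is different, with a 12-fold higher number from compound 2 to compound 4 (1.08 log units; beyond the scatter), which leaves compound 2 as the only one of the four set apart. Nothing available explains why these steps differ. Going by these compounds, whether an amine or a carboxylic acid at this chain carbon would move the number remains open. So does whether a longer chain ending in phenyl would.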